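Lipophilicity of three aminoalkylpyridine analogs and a fourth

The compounds below may be only part of what the source reports. "The series", "measured", "known", "first", "only" and "open" are said of these compounds alone.

Compound 1 `Nc1nc(C(F)(F)F)cc2c1[nH]c(=O)n2Cc1ccc(NCCN2CCCC2)nc1` — 0.8
Compound 2 `CN1CCN(CCN(C)c2ccc(Cn3c(=O)[nH]c4c(N)nc(C(F)(F)F)cc43)cn2)CC1` — 1.5
Compound 3 `CN1CCN(c2ccc(Cn3c(=O)[nH]c4c(N)nc(C(F)(F)F)cc43)cn2)CC1` — 1.8

These three share one core and differ only in the group on the pyridine ring. In a physicochemical assay for lipophilicity (a lower number here means a more polar compound, a higher number a more lipophilic compound), compound 3 gives the highest of the three numbers; compound 2 sits within the scatter of it, while compound 1 lies beyond it: a number 1.00 log units higher from compound 1 to compound 3 (beyond the scatter).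

Compound 4 `Nc1nc(C(F)(F)F)cc2c1[nH]c(=O)n2Cc1ccc(NCCN2CCCCC2)nc1` brings ((2-(piperidin-1-yl)ethyl)amino in place of 4-methylpiperazin-1-yl on an aromatic carbon). It resembles compound 1, whose group differs from that of compound 4 only in the ring size. The step of a number 1.00 log units higher from compound 1 to compound 3 (beyond the scatter) is the one that bears on this change, now reversed, so a drop beyond the scatter is expected, softened somewhat for the larger ring. For compound 4 the expected step is a number 0.60 log units lower from compound 3 to compound 4 (beyond the scatter), giving an estimated 1.2 within 0.7 to 1.7.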

Compound 4, distribution coefficient: 1.3
Beside the measured number, compound 4's estimate is 0.10 log units below it; measured number inside the range.
By their numbers in this assay, from the lowest: compound 1; then compounds 4, 2 and 3 (each within the scatter of the next, the first and the last beyond it).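

In this assay, going by these compounds alone, the change of pyrrolidin-1-yl to piperidin-1-yl on an unchanged chain gives a number 0.50 log units higher from compound 1 to compound 4 (beyond the scatter), so ring size alone moves the number at this position, which the earlier compounds could not show. The (2-(piperidin-1-yl)ethyl)amino group gives a number 0.50 log units lower from compound 3 to compound 4 (beyond the scatter) against 4-methylpiperazin-1-yl, yet a number 0.20 log units lower from compound 2 to compound 4 (within the scatter) against methyl(2-(4-methylpiperazin-1-yl)ethyl)amino. Nothing available accounts for these steps. From the compounds shown here alone, whether an azepane ring at the end of the same chain would extend the ring-size step remains open. So does what a morpholine ring would give there.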